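Swapping the N-aryl group on a pyrazole diester

This account rests on a few compounds, and the source may have more. Where it says the series, first, only, none or still open, it means among the compounds named here.

Compound 2, `CCOC(=O)c1c(-c2cc3ccccc3oc2=O)nn(-c2ccc(C)c(C)c2)c1C(=O)OCC`, in a functional assay on HeLa cells (Homo sapiens) for cytotoxicity, read by MTT assay, with a stated time of 48 h; a higher number here means a weaker inhibitor, a lower number a stronger inhibitor: 50000 nM
Compound 1, `CCOC(=O)c1c(-c2c(Cl)c3cc(C)ccc3oc2=O)nn(-c2cccc(Cl)c2)c1C(=O)OCC`, in this assay: 125000 nM

Of the two numbers in hand, compound 2 shows the lower one; compound 1 sits higher, by a gap that lies beyond the usual scatter of this assay. Both compounds share the same core, a five-membered aromatic ring with two nitrogens carrying two ethoxycarbonyl groups, and they differ in several places at once, so their two values can only be compared as a whole.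

Compound 3, `CCOC(=O)c1c(-c2cc3ccccc3oc2=O)nn(-c2cccc(F)c2)c1C(=O)OCC`, has not yet been measured. It differs from compound 2 in one place only: 3-fluorophenyl in place of 3,4-dimethylphenyl on an aromatic nitrogen. The record holds no single-point change against which to weigh this swap, so the size and direction of the step is uncertain. The expectation is that compound 3 stays within the same weak range as compound 2, with a step of a 1.2-fold higher number from compound 2 to compound 3 (0.08 log units; within the scatter) of no more than the usual scatter. Compound 3 is therefore estimated at 60000 nM, within a range of 20000 nM to 200000 nM.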

Compound 3, half-maximal inhibitory concentration: 68000 nM
Compound 3: middle estimate off by 1.1-fold (0.05 log units), on the low side; measured number inside the range.
By their numbers in this assay, from the lowest: compounds 2, 3 and 1 (each within the scatter of the next, the first and the last beyond it).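

Going by these compounds alone, this pair gives the first comparison that changes only one place: in this assay, putting 3-fluorophenyl in place of 3,4-dimethylphenyl on an aromatic nitrogen gives a 1.4-fold higher number from compound 2 to compound 3 (0.13 log units; within the scatter), so compound 2 and compound 3 cannot be told apart. The swap removes both methyl groups, brings in a fluorine and takes the group from 8 heavy atoms to 7, yet for this pair the assay registers no difference beyond the scatter, so this position accepts the exchange without a clear effect on the value. No separate measurement bears on this result.

Since this one swap alters the phenyl ring in more than one way, the compounds shown cannot separate the part played by the methyl groups from that of the fluorine, and a plain phenyl group at this position would be the natural reference. As far as these compounds go, it also remains open whether an amine or a carboxylic acid on that ring, or a longer chain in its place, would move the value beyond the scatter.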